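The source may hold more compounds than are shown below. What is called first, only, known or untested is meant among the compounds shown, and "the series" means these compounds.

Measured in a functional assay on MCF7 cells (Homo sapiens) for inhibition, read by MTT assay, with a stated time of 72 h; on this read-out lower numbers stand for stronger inhibition and higher numbers for weaker inhibition:
Compound 1 `COc1cc(OC)c(OC)cc1/C=C/C(=O)c1ccc(-c2c[nH]cn2)cc1`: > 150000 nM
Compound 2 `COc1cc(OC)c(-c2cc(=O)c3cc(Cl)ccc3o2)cc1OC`: > 150000 nM

Neither compound yields a number, and both sit at one shared ceiling, (the limit of > 150000 nM in this assay, at which 2 of the 2 values shown sit). In this assay, compound 2 gives > 150000 nM, which is a limit of the assay and not a number. Its true potency is therefore unknown.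

Compound 3 `COc1cc(OC)c(-c2cc(=O)c3cc(O)ccc3o2)cc1OC` has hydroxy in place of the chloro of compound 2, on an aromatic carbon of a six-membered aromatic ring of carbon only: hydroxy in place of chloro on an aromatic carbon. Among the compounds with values here, no measured pair shows what this exchange does, so any forecast is loose, and a further limit is quite possible. The estimated step of an at least 1.5-fold lower number from compound 2 to compound 3 (0.17 log units; that floor lies within the scatter) is expected to be modest, towards stronger inhibition, and may not exceed the scatter. For compound 3 the expected value is 100000 nM, with an estimated range from 30000 nM to 200000 nM.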

Compound 3, half-maximal inhibitory concentration: > 150000 nM
Compound 3 was reported as a limit (the forecaster's own chance of this, stated with the estimate: 55%); at least 1.5-fold (0.17 log units) between middle value and limit.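

Compound 3, with hydroxy in place of the chloro of compound 2, gives no readable step from compound 2, because both results are limits and not numbers: the limit of > 150000 nM in this assay, at which 3 of the 3 values shown sit.

On these data alone, the true potency of compound 2 and compound 3 stays open, and so does whether this exchange changes inhibition at all.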